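Bromo and hydroxy together on the benzylidene ring

The source may hold more compounds than are shown below. What is called first, only, known or untested is meant among the compounds shown, and "the series" means these compounds.

Of the compounds shown here, three with a shared core have been measured in an ADME assay on NIH3T3 cells (Mus musculus) for cytotoxicity, read by MTT assay, with a stated time of 24 h; on this read-out lower numbers stand for stronger inhibition and higher numbers for weaker inhibition. Compound 1 `O=C(CSc1nnc(-c2ccncc2)o1)N/N=C/c1ccccc1` gives 167000 nM, compound 2 `O=C(CSc1nnc(-c2ccncc2)o1)N/N=C/c1ccc(F)cc1` gives 170000 nM, and compound 3 `O=C(CSc1nnc(-c2ccncc2)o1)N/N=C/c1ccc(O)cc1` gives 158000 nM. Compound 2 holds the highest of the three numbers, but its gaps to the others are both within the scatter, so the three stand as one level.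

Compound 4 `O=C(CSc1nnc(-c2ccncc2)o1)N/N=C/c1cc(Br)ccc1O` is not yet measured. It differs from compound 2 by 5-bromo-2-hydroxyphenyl in place of 4-fluorophenyl on a carbon with a double bond to nitrogen. Within the data shown here, two measured steps bear on parts of this change: a 1.0-fold higher number from compound 1 to compound 2 (0.01 log units; within the scatter) and a 1.1-fold lower number from compound 2 to compound 3 (0.03 log units; within the scatter), and also a 1.1-fold lower number from compound 1 to compound 3 (0.02 log units; within the scatter). Each of these was within the scatter, so neither a fluoro nor a hydroxy on that ring shifted the number. Among the measured compounds shown here, no measured step involves bromine, and the hydroxy now enters as part of a 5-bromo-2-hydroxyphenyl group, so some uncertainty remains.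

Compound 4 is therefore expected to show a 1.0-fold lower number from compound 2 to compound 4 (0.01 log units; within the scatter), a step not beyond the scatter. Compound 4 is estimated at 165000 nM, with a range from 80000 nM to 340000 nM.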

Compound 4, half-maximal inhibitory concentration: 156000 nM
Beside the measured number, compound 4's estimate is 1.1-fold (0.02 log units) above it; the range from low to high includes it.
By their numbers in this assay, from the lowest: compounds 4, 3, 1 and 2 (each within the scatter of the next).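

In this assay, among these compounds, 5-bromo-2-hydroxyphenyl on the carbon with a double bond to nitrogen brings bromine into the series for the first time and puts two groups on the ring at once, yet the steps read a 1.1-fold lower number from compound 2 to compound 4 (0.04 log units; within the scatter) and a 1.0-fold lower number from compound 3 to compound 4 (0.01 log units; within the scatter) and also a 1.1-fold lower number from compound 1 to compound 4 (0.03 log units; within the scatter) when each earlier ring is replaced. The level seen with phenyl, 4-fluorophenyl and 4-hydroxyphenyl therefore also holds for this more heavily substituted ring, and all four compounds stand together. Nothing available explains why the number stays level.

From the compounds shown here alone, whether an amine or a carboxylic acid on this ring, or a longer chain in its place, would move the number remains open. The compounds shown also leave open what changes elsewhere on the shared core would do.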